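Dropping the chain methyl from compound 1

A few compounds are considered here, and "the series" means these few. Any claim that something is new, unique, unknown or untested is made for them only; others in the source may bear on it.

For the measured compounds named here, in an in vitro ADME assay on microsomes from liver (Mus musculus) for metabolic stability (a higher number here means that the compound lasts longer, a lower number that the compound disappears faster), compound 1 (`C[C@H](NC(=O)c1ccc(C#N)n1C)c1c(F)cccc1Cl`) gives 3.93 h, the higher of the two numbers available so far. Compound 2 (`C[C@H](NC(=O)c1snnc1C1CC1)c1c(F)cccc1Cl`) gives 0.542 h, lower than compound 1 by more than the usual scatter. These two compounds differ in more than one place, so their gap cannot be assigned to any single change.

Compound 3 (`Cn1c(C#N)ccc1C(=O)NCc1c(F)cccc1Cl`) departs from compound 1 in one place: hydrogen in place of methyl on a saturated chain carbon bound to an amide-type nitrogen and an aromatic carbon. Going by the values given here, no measured pair shows this change, so the size of the step has no direct support and the range must stay wide. A modest fall in this assay is expected, near the edge of the scatter, and a result within the scatter would not be surprising. The estimated change is a 2.0-fold lower number from compound 1 to compound 3 (0.29 log units; within the scatter). For compound 3, the expected half-life is 2 h, with an estimated range of 0.7 h to 5 h.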

Compound 3, half-life: 0.705 h
Compound 3: middle estimate off by 2.8-fold (0.45 log units), on the high side, within the range that was stated.
By their numbers in this assay, from the lowest: compounds 2 and 3 (each within the scatter of the next); then compound 1.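

In this assay, for the compounds shown here, the methyl on the saturated chain carbon bound to an amide-type nitrogen and an aromatic carbon now has a direct reading: hydrogen in its place gives a 5.6-fold lower number from compound 1 to compound 3 (0.75 log units; beyond the scatter), the first step that can be assigned to a single change. This step lies beyond the scatter, so in the core of compound 1 the half-life depends on whether this carbon carries the methyl, and the position cannot be treated as one where the methyl can be removed without consequence. The data give no explanation for the size of this step.

As far as these compounds go, the step rests on a single pair, so it remains open whether it carries over to the core of compound 2, where the same exchange of methyl for hydrogen would give a second reading of this change. Also open, from the compounds shown here alone, is how the half-life responds to other groups on this carbon, such as an ethyl group, a longer chain or a hydroxymethyl group, and whether any of them holds the half-life at the level of compound 1 or moves it further.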